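The compounds below may be only part of what the source reports. "The series", "measured", "known", "first", "only" and "open" are said of these compounds alone.

Measured compounds:
compound 1 `CC(C)C1C(=O)NC(c2ccc(N)cc2)c2ccccc21` — 358 mg/kg
compound 2 `CCNCC(=O)Nc1ccc(C2NC(=O)C(C)(C)c3ccccc32)cc1` — 760 mg/kg

In a toxicity assay on the whole organism with Mus musculus as the target, in the rotarod test (a higher number here means that more compound is needed for the effect, a lower number that less compound is needed), compound 1 gives 358 mg/kg. Compound 2 gives 760 mg/kg in this assay, the higher of the two numbers; the gap between compound 2 and compound 1 lies beyond the usual scatter. Among the compounds with values here, the two measured compounds differ in more than one place, so no single-point step within the measured set is available for orientation.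

Compound 3 `CC1(C)C(=O)NC(c2ccc(NC(=O)CN3CCCCC3)cc2)c2ccccc21` is not yet measured. Its change from compound 2 is piperidin-1-yl in place of ethylamino on a saturated chain carbon bound to a carbonyl carbon. Nothing in the measured pair bears directly on this change. The step from compound 2 to compound 3 in this assay is expected to stay within the scatter, leaning if anything toward a slightly lower number, as a 1.2-fold lower number from compound 2 to compound 3 (0.07 log units; within the scatter). For compound 3 the expected value in this assay is 650 mg/kg, with a range from 350 mg/kg to 1200 mg/kg.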

Compound 3, dose for half-maximal effect: > 2000 mg/kg
Compound 3: only a limit was reported (the forecaster's own chance of this, stated with the estimate: 15%); at least 3.0-fold (0.48 log units) between middle value and limit.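

In this assay compound 3 gives > 2000 mg/kg, which is a limit of the assay and not a number. Within the data shown here, this is the only single-point step so far: piperidin-1-yl in place of ethylamino on a saturated chain carbon bound to a carbonyl carbon gives an at least 2.6-fold higher number from compound 2 to compound 3 (0.42 log units; beyond the scatter), so the number in this assay depends on the group at this place. The step holds only as a minimum, and its full size cannot be read: the limit of > 2000 mg/kg in this assay, at which 1 of the 3 values shown sits.

Which part of the change matters stays open, as the ring, the larger group and the loss of the hydrogen-bond donor all arrive together. A pyrrolidin-1-yl, a morpholin-4-yl or an open-chain diethylamino group at the same place would separate these features.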